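Trifluoromethyl added to the phenyl of compound 1

The compounds below may be only part of what the source reports. "The series", "measured", "known", "first", "only" and "open" are said of these compounds alone.

Measured so far:
compound 1 `c1ccc(-c2cn3ccnc3c(-c3ccc4ncn(C5CCCCC5)c4c3)n2)cc1` gives 51.6%
compound 2 `c1cn2cc(-c3ccsc3)nc(-c3ccc4ncn(C5CCCCC5)c4c3)c2n1` gives 1.37%

In a functional assay on HCT-15 cells (Homo sapiens) for inhibition, read by sulforhodamine B assay, with a stated time of 48 h, tested at 10 uM (a higher number here means more inhibition at the concentration tested (going by the name of the read-out), a lower number less inhibition), compound 1 stands highest of the two numbers shown; the nearest is compound 2, reached by a number 50.2 percentage points lower from compound 1 to compound 2 (beyond the scatter). Compound 3 `FC(F)(F)c1cccc(-c2cn3ccnc3c(-c3ccc4ncn(C5CCCCC5)c4c3)n2)c1` differs from compound 1 by trifluoromethyl in place of hydrogen on an aromatic carbon. That one measured step swaps the whole ring and does not bear on adding a trifluoromethyl to the phenyl, so no guide exists. Compound 3 is therefore expected to stay near compound 1, estimated at 50% with a range from 20% to 80%, which means an expected step of a number 1.6 percentage points lower from compound 1 to compound 3 (within the scatter), not beyond the scatter.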

Compound 3, a percentage reported as inhibition, at one concentration (the size of the read-out at that concentration, not a potency): 0.36%
The estimate for compound 3 lay 49.6 percentage points above the measured number, and the stated range ends above it.
By their numbers in this assay, from the lowest: compounds 3 and 2 (each within the scatter of the next); then compound 1.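

In this assay, a single trifluoromethyl on the phenyl, meta to a large group, brings a number 51.2 percentage points lower from compound 1 to compound 3 (beyond the scatter) and so shows that the inhibition of compound 1 can be lost by adding to this ring, not only by replacing it. Set against the thiophen-3-yl ring, the same group gives a number 1 percentage points lower from compound 2 to compound 3 (within the scatter) and so leaves both changes at a similarly low level. Nothing measured here explains the loss. On these data alone, whether it follows from this place on the ring or from trifluoromethyl itself stays open. A methoxy group or an amine on the same carbon would help separate the two.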